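The source may report more compounds than this note shows. Statements on the series, on what has been measured and on what is new or still open speak of the compounds shown alone.

Measured compounds:
Compound 1, `CCN(c1ccc(F)cc1)S(=O)(=O)c1cc(Cl)ccc1Cl`, in an ADME assay on A549 cells (Homo sapiens) for cytotoxicity, read by MTT assay (on this read-out higher numbers stand for lower toxicity in this test and lower numbers for higher toxicity in this test), gives > 5000 nM, which is a limit of the assay and not a number.
Compound 2, `CCN(c1ccc(C)cc1)S(=O)(=O)c1cc(Cl)ccc1Cl`, in this assay gives > 25000 nM, again a limit of the assay.
Compound 3, `CCN(c1ccc(Cl)cc1C)S(=O)(=O)c1cc(Cl)ccc1Cl`, in this assay gives > 5000 nM, also a limit of the assay.

Every value in the set is therefore a limit; none of the three compounds reaches a measurable half-maximal cytotoxic concentration on these cells. Within the data shown here, the one change that occurs between measured compounds, (fluoro in place of methyl on an aromatic carbon), gives a step that the two limits leave unreadable from compound 2 to compound 1. The two limits involved are the limit of > 25000 nM in this assay, at which 1 of the 3 values shown sits, and (the limit of > 5000 nM in this assay, at which 2 of the 3 values shown sit), and the gap between them says nothing about the direction of the step. The difference between the core of compound 2 and the core of compound 3 is not broken down here.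

Compound 4, `CCN(c1ccc(Cl)cc1F)S(=O)(=O)c1cc(Cl)ccc1Cl`, is not yet measured. It differs from compound 3 by fluoro in place of methyl on an aromatic carbon. Among the measured compounds shown here, this is the same kind of change as the one from compound 2 to compound 1, but not the same: there the fluoro sits para to a large group, here it sits ortho to a large group and meta to a chloro group. Since compound 3 rests at a limit, the step from compound 3 to compound 4 is expected to be small, about a step that the limit leaves unreadable from compound 3 to compound 4. Compound 4 is expected to give roughly 15000 nM in this assay, between 4000 nM and 60000 nM, most likely reported once more as a limit.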

Compound 4, half-maximal cytotoxic concentration: > 5000 nM
Compound 4: only a limit was reported; the forecaster's own chance of this, stated with the estimate: 75%; the middle value lies beyond the limit too.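

In this assay compound 4 gives > 5000 nM, a limit of the assay and not a number. Among these compounds, compound 3 gives > 5000 nM, likewise a limit, so no step between compound 3 and compound 4 can be read. The compounds shown leave open whether fluoro in place of methyl on an aromatic carbon shifts the half-maximal cytotoxic concentration at all, and where that concentration lies for any of them.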